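Furan-2-yl in Place of Thiophen-2-yl: An Expected Value

This account rests on a few compounds, and the source may have more. Where it says the series, first, only, none or still open, it means among the compounds named here.

Measured compounds in an assay on isolated protein for inhibition of Amine oxidase [flavin-containing] A (Homo sapiens), read by fluorescence; a higher number here means a weaker inhibitor, a lower number a stronger inhibitor:
Compound 1, `O=C(/C=C/c1cccc(O)c1)c1cc(O)c(O)c([N+](=O)[O-])c1`, gives 43900 nM.
Compound 2, `CC(=O)N1N=C(c2cc(O)c(O)c([N+](=O)[O-])c2)CC1c1cccs1`, gives 86300 nM.
Compound 3, `O=C(/C=C/c1ccco1)c1cc(O)c(O)c([N+](=O)[O-])c1`, gives 60500 nM.

Compound 2 has the highest of the three numbers, but its distance to compound 3 and to compound 1 is within the scatter, so no order among the three can be claimed. Compound 4, `CC(=O)N1N=C(c2cc(O)c(O)c([N+](=O)[O-])c2)CC1c1ccco1`, differs from compound 2 by furan-2-yl in place of thiophen-2-yl on a saturated ring carbon. Within the data shown here, no measured step makes this exact exchange. The closest is a 1.4-fold higher number from compound 1 to compound 3 (0.14 log units; within the scatter), where furan-2-yl also enters, though in place of a different group and on a chain carbon rather than a saturated ring carbon. On that basis no step beyond the scatter is expected, and compound 4 is estimated at 90000 nM, within 40000 nM to 200000 nM, which means an expected 1.0-fold higher number from compound 2 to compound 4 (0.02 log units; within the scatter).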

Compound 4, half-maximal inhibitory concentration: 98000 nM
For compound 4 the middle estimate is 1.1-fold (0.04 log units) below the measured one; the measured number falls inside the stated range.
By their numbers in this assay, from the lowest: compounds 1, 3, 2 and 4 (each within the scatter of the next, the first and the last beyond it).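

Among these compounds, at the saturated ring carbon of the shared core, furan-2-yl in place of thiophen-2-yl gives a 1.1-fold higher number from compound 2 to compound 4 (0.06 log units; within the scatter) in this assay, the first direct reading of this exchange at this position. Among the compounds shown here, with sulfur or oxygen as the hetero atom of the five-membered aromatic ring, this assay does not separate the two groups here, though only this one pair speaks to it. No evidence bears on this result.

From the compounds shown here alone, whether an amine or a carboxylic acid on this carbon would give a step beyond the scatter remains open. So does the effect of replacing the acetyl group with a longer chain.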